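The source may hold more compounds than are shown below. What is called first, only, known or untested is meant among the compounds shown, and "the series" means these compounds.

Measured so far in a functional assay, with a stated time of 30 min; a higher number here means a weaker inhibitor, a lower number a stronger inhibitor:
- compound 1 `O=C(/C=C/c1ccccc1O)CC(=O)/C=C/c1cccc(O)c1O`: 23000 nM
- compound 2 `O=C(/C=C/c1ccc(O)cc1)CC(=O)/C=C/c1cccc(O)c1O`: 27000 nM

With only these two compounds measured, compound 2 cannot be separated from compound 1. Within the data shown here, the single measured step, a 1.2-fold higher number from compound 1 to compound 2 (0.07 log units; within the scatter), swaps 2-hydroxyphenyl for 4-hydroxyphenyl on a double-bonded chain carbon bound to a double-bonded chain carbon. The two values therefore show no ranking.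

The next compound, compound 3 `O=C(/C=C/c1cc(O)ccc1O)CC(=O)/C=C/c1cccc(O)c1O`, changes that same place, and its difference from compound 2 is 2,5-dihydroxyphenyl in place of 4-hydroxyphenyl on a double-bonded chain carbon bound to a double-bonded chain carbon. The measured step bears on this change only in part. Among the measured compounds shown here, it shows that exchanging one hydroxyphenyl group for another at this place gave a 1.2-fold higher number from compound 1 to compound 2 (0.07 log units; within the scatter), but no measured compound carries 2,5-dihydroxyphenyl, so the effect of this group is untested. In this assay, a small move towards a lower number is expected, with nothing clearly beyond the scatter. The expected step is a 1.7-fold lower number from compound 2 to compound 3 (0.23 log units; within the scatter). For compound 3 the estimated value is 16000 nM, with an expected range of 6000 nM to 35000 nM.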

Compound 3, half-maximal inhibitory concentration: 27000 nM
For compound 3 the middle estimate is 1.7-fold (0.23 log units) below the measured one; measured number inside the range.
By their numbers in this assay, from the lowest: compounds 1, 2 and 3 (each within the scatter of the next).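

In this assay, the exchange of 4-hydroxyphenyl for 2,5-dihydroxyphenyl on a double-bonded chain carbon bound to a double-bonded chain carbon gives no change at the digits printed from compound 2 to compound 3 (within the scatter) and so does not separate the two groups. Compound 3 also pairs with compound 1, where hydroxy in place of hydrogen on an aromatic carbon gives a 1.2-fold higher number from compound 1 to compound 3 (0.07 log units; within the scatter) and again leaves the two compounds unseparated. The earlier step covered only an exchange of one hydroxyphenyl group for another, whereas these two steps show that adding a hydroxy group to either of the earlier groups at this place gives no separation in this assay; no supporting evidence bears on this result, and the numbers alone offer no explanation.

The compounds shown leave open whether this place responds to anything other than a hydroxyphenyl group, such as a phenyl ring carrying a methoxy group or a carboxylic acid. Also open, from the compounds shown here alone, is whether a change elsewhere in the shared core, identical in compound 1, compound 2 and compound 3, would move the number beyond the scatter.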